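The source may hold more compounds than are shown below. What is called first, only, known or untested is meant among the compounds shown, and "the series" means these compounds.

Measured compounds and values:

compound 1 `O=C(/C=C/c1ccc([N+](=O)[O-])cc1)Nc1cc(Sc2ncn[nH]2)c(O)c2ccccc12` — > 100000 nM
compound 2 `Cc1nnc(Sc2cc(NC(=O)c3ccc(Cl)cc3)c3ccccc3c2O)s1` — > 100000 nM

In a functional assay on MDA-MB-231 cells (Homo sapiens) for antiproliferative activity, read by MTT assay, with a stated time of 48 h (a higher number here means a weaker inhibitor, a lower number a stronger inhibitor), compound 1 gives > 100000 nM, which is a limit of the assay and not a number. In this assay compound 2 gives > 100000 nM, likewise a limit rather than a measured number. Both values sit at the limit of > 100000 nM in this assay, at which 2 of the 2 values shown sit, so compound 2 stands at the limit together with compound 1, and no numerical ordering between the two is possible; nothing on file tells whether either compound inhibits at all below that limit.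

Compound 3 `O=C(Nc1cc(Sc2ncnc3nc[nH]c23)c(O)c2ccccc12)c1ccc(Cl)cc1` is not yet measured in this assay. It differs from compound 2 in one place: a group of 9 heavy atoms (5 carbon, 4 nitrogen; one five-membered aromatic ring with 2 hetero atoms, one six-membered aromatic ring with 2 hetero atoms) in place of a group of 6 heavy atoms (3 carbon, 2 nitrogen, 1 sulfur; one five-membered aromatic ring with 3 hetero atoms), on a sulfur. Among the compounds with values here, no step between measured compounds exists in this set, so there is no measured effect of any change at the sulfur to lean on. With both measured compounds at the limit, the expectation for the step that the limit leaves unreadable from compound 2 to compound 3 is none beyond the scatter, most probably another limit. Compound 3 is therefore estimated at 150000 nM, within a range from 40000 nM to 500000 nM.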

Compound 3, half-maximal inhibitory concentration: 23000 nM
Compound 3: the middle estimate sits 6.5-fold (0.81 log units) above what was measured, outside the stated range (below it).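

In this assay, within the data shown here, the group on the sulfur is the first place where a change gives a readable effect: an at least 4.3-fold lower number from compound 2 to compound 3 (0.63 log units; beyond the scatter), as the 5-methyl-1,3,4-thiadiazol-2-yl group gives way to a group with one five-membered and one six-membered aromatic ring. With the rest of the molecule unchanged, this shows that the group on the sulfur alone can bring the series off the limit. Compound 3 gives 23000 nM, the only actual number among the compounds shown. The step gives only a lower bound on the size of the change, since its starting value is a limit of the assay and not a number: the limit of > 100000 nM in this assay, at which 2 of the 3 values shown sit.

The compounds shown do not tell whether the effect needs both aromatic rings of the entering group, a question that a plain phenyl group or a smaller imidazole on the same sulfur would address. Among these compounds, it also remains open whether the entering group has a similar effect with other amide groups on the shared core, such as the one carried by compound 1.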